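The compounds below may be only part of what the source reports. "The series", "measured", "known", "first", "only" and "open" are said of these compounds alone.

Measured so far in an ADME assay on the whole organism (Rattus norvegicus, strain Wistar Han), at a dose of 0.05 mg/kg by the intravenous route; a higher number here means that the compound lasts longer, a lower number that the compound disappears faster:

compound 1 `C[C@@H](C(=O)Nc1ccc(F)cc1)C1CCC2C(CCCN2C(=O)c2cccc(Cl)c2)C1`: 1.6 h; 1.1 h (2 entries)
compound 2 `Cc1nccc(N2CCCC3CC(C4(C(=O)Nc5ccc(F)cc5)CCC4)CCC32)n1`: 1.7 h; 1.8 h (2 entries)
compound 3 `CC(C(=O)Nc1ccc(Cl)cc1)N1CCC2C(CCCN2C(=O)OC2CC2)C1`: 2.9 h

Compound 3 rests on one measurement, 2.9 h, while compound 1 and compound 2 each come with two entries. These three compounds differ from one another in more than one place, so none of them shows directly what a single change does in this assay.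

The next compound, compound 4 `Cc1nccc(N2CCCC3CN(C(C)C(=O)Nc4ccc(Cl)cc4)CCC32)n1`, keeps the chloro-substituted anilide side of compound 3 and changes one group: 2-methylpyrimidin-4-yl in place of cyclopropyloxycarbonyl on an amine nitrogen in a ring.

The closest guide is compound 2, which carries the same 2-methylpyrimidin-4-yl group on the core of compound 2 and gives 1.7 h; 1.8 h (2 entries). That value and the value of compound 3 are all there is to go on, so the expectation is a modest one: a small move downward that stays within the usual scatter of repeated measurements. The expected change is a 1.3-fold lower number from compound 3 to compound 4 (0.12 log units; within the scatter). The estimate for compound 4 is 2.2 h, with an expected range from 1.2 h to 4 h.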

Compound 4, mean residence time: 2.9 h
Compound 4: the middle estimate sits 1.3-fold (0.12 log units) below what was measured, within the range that was stated.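

In this assay, for the compounds shown here, compounds 3 and 4 form the first pair that differs in only one place, and the step can be read directly: no change at the digits printed from compound 3 to compound 4 (within the scatter). On this amine nitrogen in a ring, the change replaces cyclopropyloxycarbonyl, with its three-membered carbon ring and a double bond outside aromatic rings, with 2-methylpyrimidin-4-yl, a six-membered aromatic ring with 2 hetero atoms, and the mean residence time shows no difference beyond the scatter, so this pair gives no sign that the read-out depends on which of these two groups sits here. That reading rests on a single entry for each compound, and repeated entries for one compound do not always agree exactly: the several entries of compound 1 in this assay, 1.6 h; 1.1 h (2 entries)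

As far as these compounds go, it remains open whether a group of another kind on the same nitrogen, such as a plain acetyl or an unsubstituted phenyl, would also leave the mean residence time within the scatter. From the compounds shown here alone, it is equally open whether this exchange would give the same result with a fluorine instead of the chlorine on the anilide, or on a different core.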